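A few compounds are considered here, and "the series" means these few. Any claim that something is new, unique, unknown or untested is made for them only; others in the source may bear on it.

Measured compounds:
Compound 1, `Cc1ccc(C2C(C#N)=C(N)N(c3ccc(S(N)(=O)=O)cc3)C3=C2C(=O)CCC3)cc1`: in a functional assay on Ehrlich cells (Mus musculus) for antiproliferative activity, read by trypan blue exclusion, with a stated time of 2 h (on this read-out lower numbers stand for stronger inhibition and higher numbers for weaker inhibition), compound 1 gives 50 ug/mL.
Compound 2, `N#CC1=C(N)N(c2ccc(S(N)(=O)=O)cc2)C2=C(C(=O)CCC2)C1c1c(O)ccc2ccccc12`: in this assay compound 2 reaches only a limit of the assay, > 100 ug/mL.

Going by the values given here, compound 1 holds the only actual number among the two values shown; the other value is a limit, as noted in the limit of > 100 ug/mL in this assay, at which 1 of the 2 values shown sits. Among the compounds with values here, the single measured step, an at least 2.0-fold higher number from compound 1 to compound 2 (0.30 log units; that floor lies within the scatter), replaces the 4-methylphenyl group on a saturated ring carbon with 2-hydroxynaphthalen-1-yl, and its floor lies within the usual scatter, so it sets no firm direction.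

Compound 3, `Cc1ccoc1C1C(C#N)=C(N)N(c2ccc(S(N)(=O)=O)cc2)C2=C1C(=O)CCC2`, differs from compound 1 by 3-methylfuran-2-yl in place of 4-methylphenyl on a saturated ring carbon. This change touches the same saturated ring carbon as the step from compound 1 to compound 2, but the entering group is a five-membered aromatic ring with one hetero atom rather than a larger fused system, so that step bears on it only loosely. For compound 3 in this assay a step of a 1.2-fold higher number from compound 1 to compound 3 (0.08 log units; within the scatter) is expected, that is no change beyond the scatter. Compound 3 is therefore estimated at 60 ug/mL, with a range from 25 ug/mL to 150 ug/mL.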

Compound 3, half-maximal inhibitory concentration: > 100 ug/mL
Compound 3: only a limit was reported (the forecaster's own chance of this, stated with the estimate: 35%); middle value at least 1.6-fold (0.22 log units) away from the limit.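

In this assay, replacing 4-methylphenyl with 3-methylfuran-2-yl on the same saturated ring carbon gives an at least 2.0-fold higher number from compound 1 to compound 3 (0.30 log units; that floor lies within the scatter), so a second, quite different entering group also sets no firm direction at this position. Compound 3, like compound 2, reads only as a limit of the assay, and the step between these two compounds cannot be read. Going by these compounds alone, a five-membered aromatic ring with one hetero atom and the fused 2-hydroxynaphthalen-1-yl group thus end at the same reported limit, which leaves compound 1, with its 4-methylphenyl group, as the only compound with an actual number: the limit of > 100 ug/mL in this assay, at which 2 of the 3 values shown sit.

The compounds shown leave open how far compounds 2 and 3 really lie from compound 1, and so whether either change weakens inhibition beyond the scatter or only appears to at the limit. They also leave open whether the reading at this carbon depends on keeping a six-membered aromatic ring of carbon only, as a 4-chlorophenyl or 4-methoxyphenyl group there might show, or whether a pyridine ring or an open alkyl chain would give a number at all.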